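Three flat results and a fluoro-to-trifluoromethyl swap

The compounds below may be only part of what the source reports. "The series", "measured", "known", "first", "only" and "open" are said of these compounds alone.

Compound 1, `CC(C(=O)N1CCN(c2ccccc2)CC1)N1C(=O)CCC1=O`: 0%
Compound 2, `CC(C(=O)N1CCN(c2ccccc2F)CC1)N1C(=O)CCC1=O`: 0%
Compound 3, `CCC(C(=O)N1CCN(c2ccccc2F)CC1)N1C(=O)CCC1=O`: 0%

In a functional assay on the whole organism (strain Swiss) with Mus musculus as the target, in the maximal electroshock model, with a stated time of 1 h, at a dose of 100 mg/kg by the intraperitoneal route (on this read-out higher numbers stand for a stronger effect at the one dose given and lower numbers for a weaker effect), compound 1 gives 0%. In this assay compound 2 gives 0%, and compound 3 gives 0%. The two steps that join these three, no change at the digits printed from compound 1 to compound 2 (within the scatter) and no change at the digits printed from compound 2 to compound 3 (within the scatter), are both flat. Compound 2 therefore stands level with compound 1 and compound 3, with no measured difference among them.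

Compound 4, `CC(C(=O)N1CCN(c2ccccc2C(F)(F)F)CC1)N1C(=O)CCC1=O`, differs from compound 2 by trifluoromethyl in place of fluoro on an aromatic carbon. The step that bears most on this change is no change at the digits printed from compound 1 to compound 2 (within the scatter), since it alters the same aromatic carbon and produced nothing. The other step, no change at the digits printed from compound 2 to compound 3 (within the scatter), touches a different place and was equally flat. With every measured change leaving the read-out unmoved, no step beyond the scatter is expected, so the estimated step is no change at the digits printed from compound 2 to compound 4 (within the scatter). Compound 4 is therefore expected to give 0%, with a range from 0% to 10%.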

Compound 4, a percentage reported as activity, at one dose (the size of the read-out at that dose, not a potency): 25%
Compound 4: middle estimate off by 25 percentage points, on the low side; measured number above the stated range.
By their numbers in this assay, from the lowest: compounds 1, 2 and 3 (each within the scatter of the next); then compound 4.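

Within the data shown here, this aromatic carbon, ortho to a large group, is the first place where a change moves the read-out in this assay. Trifluoromethyl in place of fluoro gives a number 25 percentage points higher from compound 2 to compound 4 (beyond the scatter) and trifluoromethyl in place of hydrogen gives a number 25 percentage points higher from compound 1 to compound 4 (beyond the scatter) at the same carbon, while fluoro in place of hydrogen gave no change at the digits printed from compound 1 to compound 2 (within the scatter) there, so the position responds to some groups and not to others. Nothing measured here says why trifluoromethyl and fluoro part ways at this carbon.

Still open, from the compounds shown here alone, is whether a chlorine atom, a methoxy group or a nitrile on this carbon would also lift the read-out. Also open, going by these compounds, is whether trifluoromethyl would keep its gain alongside the extra methyl that compound 3 carries on the chain.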